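Chain-lengthened isothiocyanate analogues and cell growth inhibition

The compounds below may be only part of what the source reports. "The series", "measured", "known", "first", "only" and "open" are said of these compounds alone.

Three compounds share one core and differ only in the length of the chain carrying the isothiocyanate. Compound 1 `CN(C)C(=O)c1cc2cnc(Nc3ccc(C(=O)NCCCCN=C=S)cc3F)nc2n1C1CCCC1` has the shortest chain; in a functional assay on A549 cells (Homo sapiens) for inhibition, read by CCK-8 assay, with a stated time of 72 h, tested at 10 uM (a lower number here means a weaker effect, a higher number a stronger effect of the compound at the concentration tested), compound 1 gives 24.4%. Compound 2 `CN(C)C(=O)c1cc2cnc(Nc3ccc(C(=O)NCCCCCN=C=S)cc3F)nc2n1C1CCCC1` extends the chain by one carbon, and in this assay compound 2 gives 15.6%. Compound 3 `CN(C)C(=O)c1cc2cnc(Nc3ccc(C(=O)NCCCCCCN=C=S)cc3F)nc2n1C1CCCC1` extends it by one more, and in this assay compound 3 gives 22.9%. On these numbers compound 3 stands second highest of the three, nearest to compound 1 and furthest from compound 2, but the account shows that all three lie within the scatter of one another.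

Compound 4 `CN(C)C(=O)c1cc2cnc(Nc3ccc(C(=O)NCCCCCCCN=C=S)cc3F)nc2n1C1CCCC1` continues the series. The change from compound 3 is a group of 4 heavy atoms (2 carbon, 1 nitrogen, 1 sulfur; no ring) in place of a group of 3 heavy atoms (1 carbon, 1 nitrogen, 1 sulfur; no ring), on a saturated chain carbon, six bonds along the chain from an amide-type nitrogen.

The three measured steps all bear on this, as each is a chain extension of the same kind: a number 8.8 percentage points lower from compound 1 to compound 2 (within the scatter), a number 1.5 percentage points lower from compound 1 to compound 3 (within the scatter) and a number 7.3 percentage points higher from compound 2 to compound 3 (within the scatter). None of them left the scatter, and they do not point in one direction. No step beyond the scatter is therefore expected in this assay for compound 4, with a number 2.9 percentage points lower from compound 3 to compound 4 (within the scatter) as the expected step. Compound 4 is estimated at 20%, in a range from 8% to 32%.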

Compound 4, a percentage reported as inhibition, at one concentration (the size of the read-out at that concentration, not a potency): 12.7%
For compound 4 the middle estimate is 7.3 percentage points above the measured one, and the stated range covers the measured number.
By their numbers in this assay, from the lowest: compounds 4, 2, 3 and 1 (each within the scatter of the next, the first and the last beyond it).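

For the compounds shown here, compound 4 gives the only steps of this chain series that lie beyond the scatter in this assay, and both are modest: a number 10.2 percentage points lower from compound 3 to compound 4 (beyond the scatter) and a number 11.7 percentage points lower from compound 1 to compound 4 (beyond the scatter). These steps do not make a steady decline with chain length, as compound 2 goes against one, with a number 2.9 percentage points lower from compound 2 to compound 4 (within the scatter). At this end of the chain, the change also matches in size the earlier step with the same entering and leaving groups, and the two steps that each put in a chain longer by the same amount match as well, which fits a shared alternation between compound 1 and compound 3 on one side and compound 2 and compound 4 on the other, although the steps from compound 2 to compound 1 and to compound 3 stay within the scatter: the same change on two cores in this assay, a number 8.8 percentage points lower (within the scatter) from compound 1 to compound 2 and a number 10.2 percentage points lower (beyond the scatter) from compound 3 to compound 4, 1.4 percentage points apart, within the scatter of two such steps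

On these data alone, whether a longer chain than that of compound 4 would continue this alternation, or carry the number further in either direction, remains open. As far as these compounds go, it is also open how an amine or a carboxylic acid at the chain end, in place of the isothiocyanate, would read in this assay, and these single-concentration percentages say nothing about potency.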